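A few compounds are considered here, and "the series" means these few. Any claim that something is new, unique, unknown or untested is made for them only; others in the source may bear on it.

Compound 1 `O=C(NCc1cn(Cc2ccc(F)cc2)nn1)c1cn(-c2ccccc2)nc1-c1ccc(Cl)cc1` gives 570 nM in a functional assay on MCF7 cells (Homo sapiens) for antiproliferative activity, read by sulforhodamine B assay, with a stated time of 48 h; on this read-out lower numbers stand for stronger inhibition of growth and higher numbers for weaker inhibition of growth.
Compound 2 `COc1cc(Cn2cc(CNC(=O)c3cn(-c4ccccc4)nc3-c3ccc(Cl)cc3)nn2)cc(OC)c1` gives 150 nM in this assay.

Compound 2 holds the lower of the two numbers, and the step of a 3.8-fold lower number from compound 1 to compound 2 (0.58 log units; beyond the scatter) lies beyond the scatter. Compound 3 `COc1ccc(-c2nn(-c3ccccc3)cc2C(=O)NCc2cn(Cc3cc(OC)cc(OC)c3)nn2)cc1` differs from compound 2 by methoxy in place of chloro on an aromatic carbon. Going by the values given here, no measured step touches this place; the single measured step concerns the group on a saturated chain carbon bound to an aromatic nitrogen and offers no guide here. Compound 3 is therefore expected to come out near compound 2, a 1.3-fold higher number from compound 2 to compound 3 (0.12 log units; within the scatter), with a wide range. Compound 3 is estimated at 200 nM, between 70 nM and 600 nM.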

Compound 3, concentration for 50% growth inhibition: 700 nM
Compound 3: middle estimate off by 3.5-fold (0.54 log units), on the low side, and the stated range ends below it.
By their numbers in this assay, from the lowest: compound 2; then compounds 1 and 3 (each within the scatter of the next).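

Chloro to methoxy on this aromatic carbon, para to a large group, is not a neutral swap in this assay: it brings a 4.7-fold higher number from compound 2 to compound 3 (0.67 log units; beyond the scatter), so this place, untouched by the earlier pair, does bear on the read-out. Of the two groups tested here, chloro carries the lower number. No evidence on hand accounts for the change.

Only these two groups are shown at this place, so a fluoro, a methyl or an amine would help separate losing chloro from gaining methoxy. As far as these compounds go, whether the step holds with the 4-fluorophenyl group of compound 1 also remains open.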